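This account rests on a few compounds, and the source may have more. Where it says the series, first, only, none or still open, it means among the compounds named here.

Of the compounds shown here, three that share one core have been tested in an assay on cells for inhibition of HSP60/HSP10 (Homo sapiens), with a stated time of 60 min; a higher number here means a weaker inhibitor, a lower number a stronger inhibitor. Compound 1, `O=S(=O)(Nc1ccc2oc(-c3ccccc3)nc2c1)c1cccc(F)c1`, carries a 3-fluorophenyl on its sulfonyl sulfur. In this assay compound 1 gives > 100000 nM, which is a limit of the assay and not a number. It stands at the limit of > 100000 nM in this assay, at which 1 of the 3 values shown sits, so its exact position among the other values is not known. Compound 2, `O=S(=O)(Nc1ccc2oc(-c3ccccc3)nc2c1)c1ccc(F)c(C(F)(F)F)c1`, gives 69000 nM in this assay. Compound 3, `O=S(=O)(Nc1ccc(-c2nc3ccccc3o2)cc1)c1ccc(C(F)(F)F)cc1`, gives 50000 nM in this assay. Both of these numbers lie far toward the weak end of the scale, and the two are within the usual scatter of each other.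

Compound 4, `CS(=O)(=O)Nc1ccc2oc(-c3ccccc3)nc2c1`, has not yet been measured. It differs from compound 1 in a single place: methyl in place of 3-fluorophenyl on a sulfonyl sulfur. Within the data shown here, no step between two measured compounds is available, so the effect of this change in this assay can only be guessed from the three values given. Nothing here points to a gain in potency, so no step beyond the scatter is expected, and a limit is the likeliest outcome again. Compound 4 is expected to give about 150000 nM, within 50000 nM to 500000 nM. That estimate implies a step that the limit leaves unreadable from compound 1 to compound 4, expected to fall within the scatter.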

Compound 4, half-maximal inhibitory concentration: > 100000 nM
Compound 4: no number, only a limit; the forecaster's own chance of this, stated with the estimate: 80%; the middle value is on the limit's open side.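

No step can be read from compound 1 to compound 4, because each gives only a limit of the assay and not a number: the limit of > 100000 nM in this assay, at which 2 of the 4 values shown sit.

The compounds shown leave open whether, in this assay or elsewhere, methyl and 3-fluorophenyl on a sulfonyl sulfur of the shared core differ at all.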